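Cyano Replaced by ((tert-butyl)carbonyl)oxy on a Shared Core

The source may report more compounds than this note shows. Statements on the series, on what has been measured and on what is new or still open speak of the compounds shown alone.

Measured so far:
compound 1 `C[S+]([O-])/C=C/c1cc(=O)c2cc(C#N)ccc2o1`: > 10000 nM
compound 2 `Cc1c(/C=C/[S+](C)[O-])oc2ccccc2c1=O`: 7200 nM

Of the compounds shown here, two have been measured in a functional assay on DLD-1 cells (Homo sapiens) for cytotoxicity, with a stated time of 48 h; a higher number here means a weaker inhibitor, a lower number a stronger inhibitor. For compound 1 the result is only a limit of the assay, > 10000 nM, so no number for it is known; it sits at the limit of > 10000 nM in this assay, at which 1 of the 2 values shown sits. Compound 2 gives 7200 nM. Among the compounds with values here, these two compounds differ from each other in more than one place, so no single step between them is recorded, and their values show only that compound 2 has a number where compound 1 has a limit.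

Compound 3 `C[S+]([O-])/C=C/c1cc(=O)c2cc(OC(=O)C(C)(C)C)ccc2o1` has not yet been measured. It differs from compound 1 by ((tert-butyl)carbonyl)oxy in place of cyano on an aromatic carbon. Within the data shown here, with no measured step of this kind to lean on, the expected change is small, none beyond the usual scatter, and the estimated step is an at least 1.1-fold lower number from compound 1 to compound 3 (0.04 log units; that floor lies within the scatter). Compound 3 is therefore expected to give about 9000 nM, within a range from 3000 nM to 30000 nM.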

Compound 3, half-maximal inhibitory concentration: 8000 nM
Compound 3: the middle estimate sits 1.1-fold (0.05 log units) above what was measured, and the stated range covers the measured number.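

This position, on an aromatic carbon of the shared core, now yields a real number rather than a limit: compound 3 gives 8000 nM in this assay. Putting ((tert-butyl)carbonyl)oxy in place of cyano produces an at least 1.2-fold lower number from compound 1 to compound 3 (0.09 log units; that floor lies within the scatter), so even this much larger swap, by count of heavy atoms, does not push the value out of the measurable range. The true size of the step cannot be fixed, because one end of it is not a number: the limit of > 10000 nM in this assay, at which 1 of the 3 values shown sits.

The compounds shown leave open how other groups at this position would read, for example an amine, a carboxylic acid or a simple methoxy group. A single swap also cannot show whether the same change would act alike on a different core, such as that of compound 2.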